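The source may report more compounds than this note shows. Statements on the series, on what has been measured and on what is new or still open speak of the compounds shown alone.

Measured so far in a physicochemical assay for pharmacokinetics, read by HPLC, at pH 7.5, tested at 250 uM; on this read-out lower numbers stand for a shorter-lived compound and higher numbers for a longer-lived compound:
- compound 1 `COc1ccc2c(c1)C(=O)C(CN(C)C)CC2`: 6.8 h
- compound 2 `Cc1cc(C)c2c(c1)C(=O)C(CN(C)C)CC2`: 14.4 h
- compound 3 `CN(C)CC1Cc2ccccc2C1=O`: 0.167 h

Compound 3 stands lowest of these three, and its gaps to compound 1 and to compound 2 both lie beyond the usual scatter. The next compound to be read is compound 4 `CN(C)CC1Cc2c(cccc2C(F)(F)F)C1=O`. It carries trifluoromethyl in place of hydrogen on an aromatic carbon of compound 3, ortho to a fused ring and meta to a fused ring: trifluoromethyl in place of hydrogen on an aromatic carbon.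

Among the measured compounds shown here, no pair of measured compounds differs in one place only, so the series offers no direct measure of this change. The expectation therefore starts from compound 3 at 0.167 h, with no step beyond the scatter and a slight lean toward a shorter half-life. The estimated change is a 1.3-fold lower number from compound 3 to compound 4 (0.11 log units; within the scatter). For compound 4 the expected half-life is 0.13 h, with an estimated range of 0.04 h to 0.4 h.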

Compound 4, half-life: 28.9 h
Estimate against measurement, compound 4: 220-fold (2.35 log units) below; measured number above the stated range.
By their numbers in this assay, from the lowest: compound 3; then compound 1; then compounds 2 and 4 (each within the scatter of the next).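

In this assay, among the compounds shown here, trifluoromethyl in place of hydrogen on an aromatic carbon, ortho to a fused ring and meta to a fused ring, gives a 170-fold higher number from compound 3 to compound 4 (2.24 log units; beyond the scatter) as the first single-place step. The step is large and lies beyond the scatter, so this position on the core of compound 3 is one where a single substituent can strongly change the half-life. No measurement at hand bears on the reason for this step.

Going by these compounds, whether the step is particular to trifluoromethyl remains open, since the same aromatic carbon could instead carry chlorine or a nitrile. Also open, on these data alone, is whether trifluoromethyl on another aromatic carbon of the same core would give a step of similar size.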